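The source may hold more compounds than are shown below. What is called first, only, known or untested is meant among the compounds shown, and "the series" means these compounds.

Among the measured compounds shown here, compound 2 `COCCNc1nnc(SCC(=O)N(Cc2cccc([N+](=O)[O-])c2)c2ccc(F)cc2)s1` gives 38.6% in an assay on isolated protein for inhibition of Amine oxidase [flavin-containing] B (Homo sapiens), read by fluorescence and Amplex Red, with a stated time of 30 min, tested at 1 mM (on this read-out higher numbers stand for a stronger effect at the one concentration tested and lower numbers for a weaker effect), the lower of the two numbers measured so far, though only within the scatter of compound 1 `CCCCNc1nnc(SCC(=O)N(Cc2cccc([N+](=O)[O-])c2)c2ccc(F)cc2)s1`, which gives 40.6% in this assay; the step of a number 2 percentage points lower from compound 1 to compound 2 (within the scatter) shows that exchanging the group on the saturated chain carbon two bonds along the chain from the nitrogen on the aromatic ring left the read-out unchanged within the scatter. Compound 3 `C=CCNc1nnc(SCC(=O)N(Cc2cccc([N+](=O)[O-])c2)c2ccc(F)cc2)s1` is reached from compound 2 by vinyl in place of methoxymethyl on a saturated chain carbon bound to a nitrogen on an aromatic ring. For the measured compounds named here, the one measured step, a number 2 percentage points lower from compound 1 to compound 2 (within the scatter), is the only guide, and it touches the same chain at a different place, so the expectation for this assay is a step no larger than the scatter, in no particular direction. Compound 3 is therefore estimated at 39%, within a range from 26% to 52%, an expected step of a number 0.4 percentage points higher from compound 2 to compound 3 (within the scatter).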

Compound 3, a percentage reported as inhibition, at one concentration (the size of the read-out at that concentration, not a potency): 38.1%
Beside the measured number, compound 3's estimate is 0.9 percentage points above it, and the stated range covers the measured number.
By their numbers in this assay, from the lowest: compounds 3, 2 and 1 (each within the scatter of the next).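

In this assay, vinyl in place of methoxymethyl on a saturated chain carbon bound to a nitrogen on an aromatic ring gives a number 0.5 percentage points lower from compound 2 to compound 3 (within the scatter), and vinyl in place of propyl at the same place gives a number 2.5 percentage points lower from compound 1 to compound 3 (within the scatter). The earlier pair compared only two saturated chains, whereas the allylamino compound adds a double bond outside aromatic rings and still cannot be told apart from either of them. At this position, then, all three chains read alike at the one concentration tested. No further evidence bears on this result. The compounds shown leave open whether anything at this position can move the read-out beyond the scatter, for example a phenyl ring, a much longer chain, or a chain ending in an amine or a carboxylic acid.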